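This account rests on a few compounds, and the source may have more. Where it says the series, first, only, none or still open, it means among the compounds named here.

Measured in a physicochemical assay for solubility; a higher number here means a more soluble compound, a lower number a less soluble compound:
- compound 1 `COc1ccc2c(c1)CN(C(=O)c1cc(S(C)(=O)=O)ccc1O[C@@H](C)C(F)(F)F)C2`: 46 ug/mL
- compound 2 `C[C@H](Oc1ccc(S(C)(=O)=O)cc1C(=O)N1Cc2ccc(N3CCCC3)cc2C1)C(F)(F)F`: < 1 ug/mL, a limit of the assay
- compound 3 `C[C@H](Oc1ccc(S(C)(=O)=O)cc1C(=O)N1Cc2ccc(-c3ccncc3)cc2C1)C(F)(F)F`: 25 ug/mL

For the measured compounds named here, compound 3 has a number close to the only other real number in the set. That gap is a 1.8-fold lower number from compound 1 to compound 3 (0.26 log units; within the scatter). For compound 2 the record is the limit of < 1 ug/mL in this assay, at which 1 of the 3 values shown sits.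

The next change leads to compound 4 `C[C@H](Oc1ccc(S(C)(=O)=O)cc1C(=O)N1Cc2ccc(C3CCCCO3)cc2C1)C(F)(F)F`, with oxan-2-yl in place of pyridin-4-yl on an aromatic carbon. Going by the values given here, no measured step makes this exact exchange, so the expectation rests on neighbouring steps at an aromatic carbon. The largest change is an at least 46-fold lower number from compound 1 to compound 2 (1.66 log units; beyond the scatter), and the return from that low end is an at least 25-fold higher number from compound 2 to compound 3 (1.39 log units; beyond the scatter). Both involve pyrrolidin-1-yl, another non-aromatic ring, so a deep fall on leaving pyridin-4-yl cannot be ruled out. Against that, compound 1 reaches 46 ug/mL without any pyridin-4-yl, which shows that this group is not required for a measurable number. A small fall, probably not clearly beyond the scatter, is therefore expected, with a wide margin on the low side. The expected change is a 1.7-fold lower number from compound 3 to compound 4 (0.22 log units; within the scatter). For compound 4 the estimate is 15 ug/mL, with an expected range from 4 ug/mL to 50 ug/mL.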

Compound 4, solubility: < 1 ug/mL
Compound 4: a limit, no number; the forecaster's own chance of this, stated with the estimate: 10%; at least 15-fold (1.17 log units) between middle value and limit.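

In this assay, replacing the aromatic pyridin-4-yl with the non-aromatic oxan-2-yl gives an at least 25-fold lower number from compound 3 to compound 4 (1.39 log units; beyond the scatter), so this position can distinguish two six-membered rings that match in heavy atoms and hydrogen-bond acceptors. Replacing methoxy gives a similarly clear result, an at least 46-fold lower number from compound 1 to compound 4 (1.66 log units; beyond the scatter), while the step between compound 2 and compound 4 cannot be read, as both records are limits. The low end is therefore no longer tied to pyrrolidin-1-yl alone: among the compounds shown, both non-aromatic rings on this aromatic carbon, in compound 2 and compound 4, end at the same limit, whereas the pyridin-4-yl of compound 3 and the methoxy of compound 1 do not: the limit of < 1 ug/mL in this assay, at which 2 of the 4 values shown sit.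

The compounds shown leave open whether the loss of the aromatic ring is what matters, or only these two particular non-aromatic rings, and a plain phenyl ring at this position would help to separate those readings. Going by these compounds, it also remains open whether a non-aromatic ring carrying an amine, such as piperazin-1-yl, or a carboxylic acid would give a real number rather than a limit.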